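A few compounds are considered here, and "the series" means these few. Any claim that something is new, unique, unknown or untested is made for them only; others in the source may bear on it.

Of the compounds shown here, two that share one core have been tested in a functional assay on CCRF-CEM cells (Homo sapiens) for antiproliferative activity, with a stated time of 72 h; on this read-out lower numbers stand for an effect already at smaller amounts and higher numbers for an effect only at larger amounts of compound. Compound 1 is `Cc1cn([C@@H]2O[C@H](CO)[C@@H](CF)[C@H]2O)c(=O)[nH]c1=O`. In this assay compound 1 reaches only the limit > 100 uM, so no number is known for it. Compound 2 is `Cc1cn([C@@H]2O[C@H](CO)[C@@H](CN)[C@@H]2O)c(=O)[nH]c1=O`. In this assay compound 2 likewise reaches only the limit > 100 uM, which is not a number. Among the measured compounds shown here, compound 2 therefore stands where every value so far stands: the limit of > 100 uM in this assay, at which 2 of the 2 values shown sit, with nothing to set it apart from compound 1. For the measured compounds named here, no pair of measured compounds differs in a single place, so no measured step is available to guide what follows.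

Compound 3 is `Cc1cn([C@@H]2O[C@H](CO)[C@@H](CO)[C@@H]2O)c(=O)[nH]c1=O`. It differs from compound 2 by one change: hydroxy in place of amino on a saturated chain carbon bound to a saturated ring carbon. Because compound 2 gives only the limit > 100 uM, the expectation for this step is none beyond the scatter, an estimated step that the limit leaves unreadable from compound 2 to compound 3. Compound 3 is expected to give about 150 uM in this assay, within an estimated range from 50 uM to 500 uM, and most likely the assay will again report only a limit for compound 3.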

Compound 3, concentration for half-maximal effect: > 100 uM
Compound 3 was reported as a limit (the forecaster's own chance of this, stated with the estimate: 85%); the middle value lies beyond the limit too.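

No size can be read for the change from compound 2 to compound 3, hydroxy in place of amino, because both compounds give only a limit and not a number: the limit of > 100 uM in this assay, at which 3 of the 3 values shown sit. The compounds shown leave open whether any change on the shared core brings a measurable effect in this assay within the tested range.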